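Swapping bromo for iodo at the assay limit

The source may report more compounds than this note shows. Statements on the series, on what has been measured and on what is new or still open speak of the compounds shown alone.

compound 1 `COc1ccc(C(=O)/C=C/c2ccccc2)c(O)c1Br`: > 50000 nM
compound 2 `CCCOc1ccc(C(=O)/C=C/c2ccccc2)c(O)c1`: > 50000 nM
compound 3 `COc1cc(O)c(C(=O)/C=C/c2ccccc2)cc1Br`: > 50000 nM

Each of these entries is a limit and not a number. In a functional assay on MCF7 cells (Homo sapiens) for antiproliferative activity, with a stated time of 48 h (a lower number here means a stronger inhibitor, a higher number a weaker inhibitor), compound 1 stands at the limit of > 50000 nM in this assay, at which 3 of the 3 values shown sit, and cannot be ranked against the others. Compound 4 `COc1ccc(C(=O)/C=C/c2ccccc2)c(O)c1I` has yet to be measured. It carries iodo in place of bromo on an aromatic carbon, ortho to a hydroxy group and ortho to a methoxy group. For the measured compounds named here, no measured pair shows what such a swap does, so no shift beyond the scatter is expected in this assay, in either direction. The estimated step of a number no higher from compound 1 to compound 4 (the limit leaves the size open) is expected to be small. Compound 4 is estimated at 50000 nM as its half-maximal inhibitory concentration, with an expected range from 20000 nM to 100000 nM and a good chance of another limit.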

Compound 4, half-maximal inhibitory concentration: > 50000 nM
Compound 4: no number, only a limit; the forecaster's own chance of this, stated with the estimate: 70%; the middle value lies on the limit itself.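

The step from compound 1 to compound 4, iodo in place of bromo, cannot be read, since both entries are limits and not numbers: the limit of > 50000 nM in this assay, at which 4 of the 4 values shown sit.

The compounds shown leave open how any of them ranks in this assay, and what this swap does there.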